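Replacing the penta-1,3-dien-1-yl chain of compound 2

This account rests on a few compounds, and the source may have more. Where it says the series, first, only, none or still open, it means among the compounds named here.

Three related compounds have been tested in a functional assay on HCT-116 cells (Homo sapiens) for inhibition, read by MTT assay, with a stated time of 48 h (a lower number here means a stronger inhibitor, a higher number a weaker inhibitor), and one of them stands apart. Compound 2 `C/C=C/C=C/C(=O)N(Cc1ccc(OC)c(O)c1)c1cc(OC)c(OC)c(OC)c1` gives 180 nM and has the lowest number of the three, well beyond the usual scatter of repeat measurements. In the same test compound 1 `C/C=C/C(=O)N(Cc1ccc(OC)c(OC)c1)c1cc(OC)c(OC)c(OC)c1` gives 32800 nM and compound 3 `C/C=C/C(=O)N(Cc1ccc(OC)c(C)c1)c1cc(OC)c(OC)c(OC)c1` gives 23500 nM as its result.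

The next molecule, compound 4 `COc1ccc(CN(C(=O)CCCCCl)c2cc(OC)c(OC)c(OC)c2)cc1O`, differs from compound 2 in one place, with 4-chlorobutyl in place of penta-1,3-dien-1-yl on a carbonyl carbon. The full count is 4-chlorobutyl in place of penta-1,3-dien-1-yl on a carbonyl carbon and shows a chain with double bonds giving way to one without them.

Going by the values given here, the only measured step, a 1.4-fold lower number from compound 1 to compound 3 (0.14 log units; within the scatter), swaps methyl for methoxy on an aromatic carbon and stays within the scatter, so it says nothing about this chain. Among the compounds with values here, compound 2 differs from compound 1 in more than one place, so no measured step isolates the chain. Within the data shown here, the only hint is that compound 1, which lacks this chain, sits at 32800 nM in this assay and so a move to a higher number is expected.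

The expected size of the change is a 17-fold higher number from compound 2 to compound 4 (1.22 log units; beyond the scatter) on this estimate. Compound 4 is estimated at 3000 nM with an expected range of 400 nM to 25000 nM in this test.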

Compound 4, half-maximal inhibitory concentration: 220 nM
Beside the measured number, compound 4's estimate is 14-fold (1.13 log units) above it, outside the stated range (below it).
By their numbers in this assay, from the lowest: compounds 2 and 4 (each within the scatter of the next); then compounds 3 and 1 (each within the scatter of the next).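

In this assay the change of chain on the carbonyl carbon reads a 1.2-fold higher number from compound 2 to compound 4 (0.09 log units; within the scatter), so compound 2 and compound 4 cannot be told apart in this test, even though the chain that enters has none of the 2 double bonds of the one that leaves and carries a chlorine atom. Going by these compounds alone, this is the first direct look at this position, and it shows that, with the rest of compound 2 held fixed, the penta-1,3-dien-1-yl chain and its double bonds are not needed for a number in this range, since 4-chlorobutyl serves just as well. Nothing shown here offers any measured explanation of why these two chains give matching results.

Whether the chlorine atom itself contributes stays open, since a plain butyl chain without it is absent from the compounds shown, and so is a chain ending in an amine or a carboxylic acid. How much length this position tolerates is also unknown, as a longer chain such as octyl, or a much shorter one such as methyl, does not appear on this same background.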